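The compounds below may be only part of what the source reports. "The series", "measured", "known", "first", "only" and "open" are said of these compounds alone.

Measured so far:
compound 1, `O=c1[nH]cc(S(=O)(=O)Nc2cccc(-c3cn(-c4ccc(F)cc4)nn3)c2)c(=O)[nH]1`, > 20000 nM
compound 2, `O=c1[nH]cc(S(=O)(=O)Nc2cccc(-c3cn(-c4ccccc4Cl)nn3)c2)c(=O)[nH]1`, 3010 nM
compound 3, `O=c1[nH]cc(S(=O)(=O)Nc2ccc(-c3cn(-c4ccc(F)cc4)nn3)cc2)c(=O)[nH]1`, > 20000 nM

In a functional assay on SGC-7901 cells (Homo sapiens) for antiproliferative activity, read by MTT assay, with a stated time of 24 h (on this read-out lower numbers stand for stronger inhibition and higher numbers for weaker inhibition), compound 1 reaches only a limit of the assay, > 20000 nM. Compound 2, by contrast, gives 3010 nM in this assay. The change between them, (2-chlorophenyl in place of 4-fluorophenyl on an aromatic nitrogen), made a step of an at least 6.6-fold lower number from compound 1 to compound 2 (0.82 log units; beyond the scatter). Compound 3 also sits at a limit of the assay in this assay, > 20000 nM. How the core of compound 3 differs from that of compound 1 is not broken down here.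

Compound 4, `O=c1[nH]cc(S(=O)(=O)Nc2ccc(-c3cn(-c4ccccc4Cl)nn3)cc2)c(=O)[nH]1`, has not yet been measured. It carries the same change relative to compound 3, (2-chlorophenyl in place of 4-fluorophenyl on an aromatic nitrogen), as compound 2 carries relative to compound 1. Compound 4 is expected to show a step of about an at least 2.5-fold lower number from compound 3 to compound 4 (0.39 log units; beyond the scatter) in this assay, resting on an at least 6.6-fold lower number from compound 1 to compound 2 (0.82 log units; beyond the scatter) and on (the limit of > 20000 nM in this assay, at which 2 of the 3 values shown sit). Compound 4 is therefore estimated at 8000 nM, between 2500 nM and 25000 nM.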

Compound 4, half-maximal inhibitory concentration: 2680 nM
Estimate against measurement, compound 4: 3.0-fold (0.47 log units) above; measured number inside the range.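

In this assay, 2-chlorophenyl in place of 4-fluorophenyl on the aromatic nitrogen gave a step of an at least 7.4-fold lower number from compound 3 to compound 4 (0.87 log units; beyond the scatter). The change thus lowers the number in the same direction on both cores shown: the same change on two cores in this assay, an at least 6.6-fold lower number (0.82 log units; beyond the scatter) from compound 1 to compound 2 and an at least 7.4-fold lower number (0.87 log units; beyond the scatter) from compound 3 to compound 4; the limit leaves it open whether they differ This does not show how large either step really is, nor that the change would carry over to any core beyond these two.

The compounds shown leave open what a 4-chlorophenyl, a 2-fluorophenyl or an unsubstituted phenyl group would give on either core. They therefore do not separate the effect of swapping fluorine for chlorine from that of moving the halogen on the phenyl ring.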